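The compounds below may be only part of what the source reports. "The series", "measured", "known", "first", "only" and "open" are said of these compounds alone.

Working notes on the series, read in an ADME assay on L132 cells (Homo sapiens) for cytotoxicity, read by MTT assay, with a stated time of 72 h; a higher number here means a weaker inhibitor, a lower number a stronger inhibitor. Compound 1 `COc1ccc(C2=C(c3cc(OC)c(OC)c(OC)c3)C(=O)CC2O[SiH2]C(C)(C)C)cc1` gives > 100 ug/mL. That value is a limit of the assay and not a number. Among the compounds with values here, compound 2 `COCOc1cc(C2=C(c3cc(OC)c(OC)c(OC)c3)C(=O)CC2O[SiH2]C(C)(C)C)ccc1OC` gives 32 ug/mL, the only true number so far. Within the data shown here, the one measured step is an at least 3.1-fold lower number from compound 1 to compound 2 (0.49 log units; beyond the scatter), which lies beyond the scatter and comes with methoxymethoxy in place of hydrogen on an aromatic carbon.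

Next is compound 3 `COc1cc(C2=C(c3cc(C)c(OC)c(C)c3)C(O[SiH2]C(C)(C)C)CC2=O)cc(OC)c1OC`, with the change 4-methoxy-3,5-dimethylphenyl in place of 4-methoxy-3-(methoxymethoxy)phenyl on a double-bonded ring carbon. Compound 3 no longer carries the methoxymethoxy group whose arrival came with an at least 3.1-fold lower number from compound 1 to compound 2 (0.49 log units; beyond the scatter), so part of that step may be given back. Among the measured compounds shown here, the 4-methoxy-3,5-dimethylphenyl group has no measured precedent, so the range stays wide. A modest move towards a higher number in this assay is expected, and the estimated size is a 1.9-fold higher number from compound 2 to compound 3 (0.27 log units; within the scatter). For compound 3 the estimate is 60 ug/mL, with an expected range of 25 ug/mL to 150 ug/mL.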

Compound 3, half-maximal inhibitory concentration: > 100 ug/mL
Compound 3: only a limit was reported; the forecaster's own chance of this, stated with the estimate: 35%; at least 1.6-fold (0.22 log units) between middle value and limit.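

On the double-bonded ring carbon, the aryl group now shows an effect in the upward direction as well: 4-methoxy-3,5-dimethylphenyl in place of 4-methoxy-3-(methoxymethoxy)phenyl comes with an at least 3.1-fold higher number from compound 2 to compound 3 (0.49 log units; beyond the scatter). In this assay compound 3 gives > 100 ug/mL, which is a limit of the assay and not a number. The step from compound 1 to compound 3 cannot be read, so the 4-methoxyphenyl and 4-methoxy-3,5-dimethylphenyl groups cannot be ordered, and compound 2, with its methoxymethoxy group, is the only compound that gives a true number: the limit of > 100 ug/mL in this assay, at which 2 of the 3 values shown sit.

Still open, as far as these compounds go, is whether the true number of compound 2 depends on the methoxymethoxy group itself or would also appear with a hydroxyl, an amine or a longer alkoxy chain on the same phenyl ring. From the compounds shown here alone, how far compound 1 and compound 3 lie beyond their limits also stays open, and with it any order among the groups that do not reach a true number.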